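A few compounds are considered here, and "the series" means these few. Any claim that something is new, unique, unknown or untested is made for them only; others in the source may bear on it.

In an ADME assay on the whole organism (blood, Rattus norvegicus, strain Sprague-Dawley) for metabolic stability, read by LC-MS (on this read-out higher numbers stand for a longer-lived compound and lower numbers for a shorter-lived compound), compound 2 `CC(C)n1nccc1-c1ncccc1COc1cccnc1C=O` gives 0.7 h, the lowest of the three numbers in hand, while compound 1 `COCCOc1cc(C=O)c(OCc2cccnc2-c2ccnn2C(C)C)cn1` gives 1.5 h and compound 3 `Cc1ccc(OCc2cccnc2-c2ccnn2C(C)C)c(C=O)n1` gives 1.5 h. Compound 4 `CC(C)n1nccc1-c1ncccc1COc1ccccc1C=O` is related to compound 2 by 2-formylphenyl in place of 2-formylpyridin-3-yl on an oxygen on a saturated carbon, with 2-formylphenyl in place of 2-formylpyridin-3-yl on an oxygen on a saturated carbon. Among the compounds with values here, only one measured step starts from compound 2, a 2.1-fold higher number from compound 2 to compound 3 (0.33 log units; beyond the scatter), which is modest and involves a different change, a methyl in place of hydrogen on an aromatic carbon, so it offers only a rough guide to size. A similarly modest rise is expected in this assay, a 1.7-fold higher number from compound 2 to compound 4 (0.23 log units; within the scatter), though no change at all remains possible. Compound 4 is estimated at 1.2 h, with an expected range of 0.5 h to 2.8 h.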

Compound 4, half-life: 2.1 h
The estimate for compound 4 lay 1.8-fold (0.24 log units) below the measured number, and the stated range covers the measured number.
By their numbers in this assay, from the lowest: compound 2; then compounds 1, 3 and 4 (each within the scatter of the next).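

In this assay, 2-formylphenyl in place of 2-formylpyridin-3-yl on an oxygen on a saturated carbon gives a 3.0-fold higher number from compound 2 to compound 4 (0.48 log units; beyond the scatter), a step beyond the scatter. Within the data shown here, until now, the only step from compound 2 was the methyl change, a 2.1-fold higher number from compound 2 to compound 3 (0.33 log units; beyond the scatter); this result shows that the number also moves when the ring nitrogen is replaced by carbon, with the formyl group kept. Nothing measured here accounts for this rise. As far as these compounds go, whether a carboxylic acid in place of the formyl group, or an amine on the carbon-only ring, would keep this number remains open.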